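The source may hold more compounds than are shown below. What is called first, only, known or untested is meant among the compounds shown, and "the series" means these compounds.

Two compounds of the series have a number in an assay on isolated protein for inhibition of Rho-associated protein kinase 1 (Homo sapiens), read by scintillation counting, radiometric assay and 33P incorporation, with a stated time of 40 min, in the presence of a further agent that is not named here; on this read-out lower numbers stand for stronger inhibition and higher numbers for weaker inhibition. Compound 1 `CC(C)(C)c1cc(C(=O)Nc2cccc(NC(=O)COc3ccc4c(=O)ccoc4c3)c2)no1` gives 101 nM. Compound 2 `CN(C)c1ccc(S(=O)(=O)Nc2cccc(NC(=O)COc3ccc4c(=O)ccoc4c3)c2)cc1` gives 803 nM, the higher of the two numbers, a gap beyond the scatter. Compound 3 `O=C(COc1ccc2c(=O)ccoc2c1)Nc1cccc(NS(=O)(=O)c2ccc(C(F)(F)F)cc2)c1` carries the change (trifluoromethyl in place of dimethylamino on an aromatic carbon), trifluoromethyl in place of dimethylamino on an aromatic carbon. Among the compounds with values here, no measured pair shows this change, so no step size is known; the expected step of a 1.1-fold lower number from compound 2 to compound 3 (0.06 log units; within the scatter) is small, in either direction, and may stay within the scatter. Compound 3 is expected at 700 nM, within 250 nM to 2500 nM.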

Compound 3, half-maximal inhibitory concentration: > 10000 nM
Compound 3: no number, only a limit; the forecaster's own chance of this, stated with the estimate: 3%; at least 14-fold (1.15 log units) between middle value and limit.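

Compound 3 gives > 10000 nM in this assay, a limit and not a number. The position para to a large group is therefore not indifferent to this change: trifluoromethyl in place of dimethylamino gives an at least 12-fold higher number from compound 2 to compound 3 (1.09 log units; beyond the scatter). That step is a lower bound only, and its full size cannot be read: the limit of > 10000 nM in this assay, at which 1 of the 3 values shown sits.

Still open, on these data alone, is whether the loss follows from removing dimethylamino or from introducing trifluoromethyl. Methoxy, a primary amine or a plain hydrogen at this place would bear on that question.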